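Halogen Swap on the Shared Core: Toward Compound 4

The source may hold more compounds than are shown below. What is called first, only, known or untested is meant among the compounds shown, and "the series" means these compounds.

Measured so far in an ADME assay on RAW264.7 cells (Mus musculus) for cytotoxicity, read by MTT assay, with a stated time of 24 h; a higher number here means that more compound is tolerated, a lower number that less compound is tolerated:
Compound 1 `O=C(Nc1ccc(F)cc1F)c1cc(F)ccc1O` gives 15700 nM.
Compound 2 `O=C(Nc1ccc(Br)cc1F)c1cc(I)ccc1O` gives 8400 nM.
Compound 3 `O=C(Nc1ccc(F)cc1F)c1cc(I)ccc1O` gives 13700 nM.

Compound 3 stands second highest of the three numbers, with compound 1 closest and compound 2 furthest, yet every gap among them lies within the scatter, so no ordering can be drawn. Compound 4 `O=C(Nc1ccc(Cl)cc1F)c1cc(I)ccc1O` is the next compound. It differs from compound 3 by chloro in place of fluoro on an aromatic carbon.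

Within the data shown here, only one measured step touches the same position: a 1.6-fold higher number from compound 2 to compound 3 (0.21 log units; within the scatter), which moved the number within the scatter. The other step, a 1.1-fold lower number from compound 1 to compound 3 (0.06 log units; within the scatter), concerns a different part of the shared core and was likewise within the scatter. Chloro stands between fluoro and bromo in the series of halogens already sampled at this place, so any shift should be modest. The account therefore expects no step beyond the scatter for compound 4, the estimated change being a 1.2-fold lower number from compound 3 to compound 4 (0.10 log units; within the scatter). Compound 4 is estimated at 11000 nM in this assay, within a range of 6000 nM to 20000 nM.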

Compound 4, half-maximal cytotoxic concentration: 8500 nM
Beside the measured number, compound 4's estimate is 1.3-fold (0.11 log units) above it; low and high end bracket the measured number.
By their numbers in this assay, from the lowest: compounds 2, 4, 3 and 1 (each within the scatter of the next).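

In this assay, at the aromatic carbon para to a large group and meta to a fluoro group, chloro in place of fluoro gives a 1.6-fold lower number from compound 3 to compound 4 (0.21 log units; within the scatter), and chloro in place of bromo gives a 1.0-fold higher number from compound 2 to compound 4 (0.01 log units; within the scatter). With fluoro, chloro and bromo now all read at this place on the shared core, compounds 2, 3 and 4 lie within the scatter of one another, so this halogen swap shows no difference that this assay can resolve. No evidence is available on what lies behind these numbers.

On these data alone, it remains open whether an amine, a carboxylic acid or a longer chain at this place would give a step beyond the scatter. Also open, as far as these compounds go, is whether chloro or bromo here would read the same way with fluoro in place of iodo on the other ring of the shared core.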